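From Dichlorophenyl to Fluoronitrophenyl on a Sulfonyl Sulfur

A few compounds are considered here, and "the series" means these few. Any claim that something is new, unique, unknown or untested is made for them only; others in the source may bear on it.

Compound 1 `Cn1c(=O)c(S(=O)(=O)c2ccc(Cl)cc2Cl)cc2cnc(Nc3ccc4[nH]ccc4c3)nc21`: 1000 nM
Compound 2 `O=c1c(S(=O)(=O)c2ccc(F)cc2F)cc2cnc(Nc3ccc4[nH]ccc4c3)nc2n1C1CCCC1`: 5000 nM
Compound 3 `Cn1c(=O)c(S(=O)(=O)c2ccc(Cl)cc2)cc2cnc(Nc3cccc4[nH]ccc34)nc21`: 5000 nM

These three were measured in a functional assay on K562 cells (Homo sapiens) for inhibition, read by trypan blue exclusion, with a stated time of 72 h; a higher number here means a weaker inhibitor, a lower number a stronger inhibitor. Compound 1 has the lowest number of the three; compound 2 and compound 3 each sit at a higher number, and both gaps lie beyond the scatter. The untested compound 4 `Cn1c(=O)c(S(=O)(=O)c2ccc(F)cc2[N+](=O)[O-])cc2cnc(Nc3ccc4[nH]ccc4c3)nc21` differs from compound 1 in one place: 4-fluoro-2-nitrophenyl in place of 2,4-dichlorophenyl on a sulfonyl sulfur. Among the measured compounds shown here, no pair of measured compounds shows this change, so its effect cannot be read from the data. A small step is expected in this assay, a 1.5-fold higher number from compound 1 to compound 4 (0.18 log units; within the scatter), possibly no larger than the scatter. Compound 4 is therefore expected to give about 1500 nM in this assay, with a range from 500 nM to 5000 nM.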

Compound 4, half-maximal inhibitory concentration: 900 nM
The estimate for compound 4 lay 1.7-fold (0.22 log units) above the measured number; the measured number falls inside the stated range.
By their numbers in this assay, from the lowest: compounds 4 and 1 (each within the scatter of the next); then compounds 2 and 3 (each within the scatter of the next).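

In this assay, among the compounds shown here, the change from 2,4-dichlorophenyl to 4-fluoro-2-nitrophenyl on a sulfonyl sulfur gives the first readable step at this position: a 1.1-fold lower number from compound 1 to compound 4 (0.05 log units; within the scatter). The two groups therefore read alike here, even though the entering group has more heavy atoms and carries hydrogen-bond acceptors that the leaving group lacks. Nothing at hand explains why the two read alike.

Going by these compounds, whether an amine or a carboxylic acid on this phenyl ring would also read alike remains open. Compound 2 and compound 3 differ from compound 1 in more than one place, so their gaps cannot be read as the effect of any single change.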